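This account rests on a few compounds, and the source may have more. Where it says the series, first, only, none or still open, it means among the compounds named here.

Compound 1 `COc1cc(-c2nnc(SC)n2/N=C/c2ccccc2)cc(OC)c1OC` gives 28500 nM in a functional assay on MKN-45 cells (Homo sapiens) for cytotoxicity, read by MTT assay, with a stated time of 48 h; a lower number here means a stronger inhibitor, a higher number a weaker inhibitor.
Compound 2 `COc1ccc(/C=N/n2c(SC)nnc2-c2cc(OC)c(OC)c(OC)c2)c(OC)c1` gives in this assay only a limit, not a number: > 200000 nM.
Compound 3 `COc1cc(-c2nnc3n2NC(CC(=O)c2ccc(C)cc2)(c2ccccc2)S3)cc(OC)c1OC` gives 7470 nM in this assay.

Among the two numbers, compound 3 stands lowest, that is, as the stronger inhibitor; compound 1 sits an at least 7.0-fold higher number from compound 1 to compound 2 (0.84 log units; beyond the scatter) step is the only one measured, and it concerns a different position, so nothing measured speaks directly to what follows. Compound 4 `CCOC(=O)CC1(c2ccccc2)Nn2c(nnc2-c2cc(OC)c(OC)c(OC)c2)S1` differs from compound 3 in one place: ethoxy in place of 4-methylphenyl on a carbonyl carbon. The shared core is untouched. Within the data shown here, with no measured step at this position, the expectation rests only on the size of the change in the side chain. From compound 3 to compound 4 a change of a 1.6-fold higher number from compound 3 to compound 4 (0.21 log units; within the scatter) is expected, toward a somewhat weaker inhibitor but not far beyond the scatter. Compound 4 is therefore estimated at 12000 nM, with a range from 3500 nM to 40000 nM.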

Compound 4, half-maximal inhibitory concentration: > 200000 nM
Compound 4 ended at the assay's limit (the forecaster's own chance of this, stated with the estimate: 10%); middle value at least 16-fold (1.22 log units) away from the limit.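

In this assay, putting ethoxy in place of 4-methylphenyl on the carbonyl carbon gives an at least 26-fold higher number from compound 3 to compound 4 (1.42 log units; beyond the scatter). Among these compounds, this is the first measured change at this side chain, and it shows that the group on the carbonyl carbon matters a great deal to the number, even with the shared core untouched. Compound 4 gives only a limit, not a number, so the true size of the step stays unknown, and this is the same limit reached by compound 2: the limit of > 200000 nM in this assay, at which 2 of the 4 values shown sit.

The swap removes a six-membered aromatic ring and brings in an oxygen at the same time, so this one pair cannot show which of the two changes counts. On these data alone, it also remains open whether a plain phenyl, a methyl or an amine on the same carbonyl carbon would keep the inhibition seen for compound 3.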